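Nitro to methoxy on the sulfonyl aryl ring

The source may report more compounds than this note shows. Statements on the series, on what has been measured and on what is new or still open speak of the compounds shown alone.

The measured compounds and their values:
compound 1, `C/C(=N\NC(N)=S)C1c2ccccc2CCN1S(=O)(=O)c1ccc(C)cc1`, gives > 50 ug/mL in a functional assay on A549 cells (Homo sapiens) for cytotoxicity, read by crystal violet staining, with a stated time of 3 days; on this read-out higher numbers stand for weaker inhibition and lower numbers for stronger inhibition.
compound 2, `C/C(=N\NC(N)=S)C1c2ccccc2CCN1S(=O)(=O)c1ccc([N+](=O)[O-])cc1`, gives > 50 ug/mL in this assay.

For compound 2 the value of > 50 ug/mL in this assay is a limit of the assay, not a number. For compound 1 the value of > 50 ug/mL in this assay is likewise a limit. Among the measured compounds shown here, the step that the two limits leave unreadable from compound 1 to compound 2 therefore cannot be read, and the only evidence is the limit of > 50 ug/mL in this assay, at which 2 of the 2 values shown sit.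

Compound 3, `COc1ccc(S(=O)(=O)N2CCc3ccccc3C2/C(C)=N/NC(N)=S)cc1`, differs from compound 2 by methoxy in place of nitro on an aromatic carbon. For the measured compounds named here, no measured step bears on this change, since the one step available is unreadable. With both neighbours of compound 3 at the limit, compound 3 is expected to give 60 ug/mL in this assay, within 25 ug/mL to 150 ug/mL, most likely reported as a limit again. The step that the limit leaves unreadable from compound 2 to compound 3 that this estimate implies is expected to be none beyond the scatter.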

Compound 3, half-maximal inhibitory concentration: > 50 ug/mL
Compound 3 gave a limit, no number; the forecaster's own chance of this, stated with the estimate: 80%; the middle value is on the limit's open side.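

Compound 3 gives > 50 ug/mL and this is a limit of the assay, not a number. Among the compounds shown here, no step among compound 1, compound 2 and compound 3 can therefore be read: the limit of > 50 ug/mL in this assay, at which 3 of the 3 values shown sit. The compounds shown leave open whether methyl, nitro or methoxy on the aromatic carbon makes any difference to cytotoxicity.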